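The compounds below may be only part of what the source reports. "The series", "measured", "known", "first", "only" and "open" are said of these compounds alone.

Of the compounds shown here, three have been tested in an ADME assay on Vero cells (Chlorocebus sabaeus) for cytotoxicity, read by neutral red uptake, tested at 787 ug/mL; a higher number here means a weaker effect of the compound at the concentration tested, a lower number a stronger effect. Compound 1 `COc1ccc(C2SCC(=O)N2CCN2CCCCC2)cc1` gives 33%, compound 2 `O=C1CSC(c2ccc(F)cc2)N1CCN1CCCCC1` gives 17%, and compound 3 `O=C1CSC(c2cccc(F)c2)N1CCN1CCCCC1` gives 27%. Compound 1 arises from compound 2 by methoxy in place of fluoro on an aromatic carbon, a change that made a step of a number 16 percentage points higher from compound 2 to compound 1 (beyond the scatter). Compound 3 arises from compound 2 by 3-fluorophenyl in place of 4-fluorophenyl on a saturated ring carbon, with a step of a number 10 percentage points higher from compound 2 to compound 3 (within the scatter). Compound 4 `COc1cccc(C2SCC(=O)N2CCN2CCCCC2)c1` has not yet been measured; it differs from compound 3 by methoxy in place of fluoro on an aromatic carbon. Among the measured compounds shown here, this is the same kind of change as the one from compound 2 to compound 1, though here the methoxy sits meta to a large group rather than para to it. Because the earlier change gave a number 16 percentage points higher from compound 2 to compound 1 (beyond the scatter), a step of about a number 15 percentage points higher from compound 3 to compound 4 (beyond the scatter) is expected. For compound 4 the estimate in this assay is 42%, within a range from 30% to 55%.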

Compound 4, a percentage reported as activity, at one concentration (the size of the read-out at that concentration, not a potency): 19%
Compound 4: middle estimate off by 23 percentage points, on the high side, outside the stated range (below it).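

In this assay, methoxy in place of fluoro gives a number 8 percentage points lower from compound 3 to compound 4 (within the scatter). On the evidence of these two pairs, the same change does not carry over as a fixed step from one core to the other: the same change on two cores in this assay, a number 16 percentage points higher (beyond the scatter) from compound 2 to compound 1 and a number 8 percentage points lower (within the scatter) from compound 3 to compound 4, 24 percentage points apart, beyond the scatter of two such steps The pairs show that a step measured on one core cannot simply be assumed on another, but they do not show why the two steps differ or how the change would behave on any further core.

Still open, from the compounds shown here alone, is how other groups on the aromatic ring, such as chloro or an amine, would behave in this assay. Also open, going by these compounds, is whether a longer chain linking the two nitrogen-bearing rings would alter the picture.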